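The compounds below may be only part of what the source reports. "The series", "measured", "known", "first", "only" and "open" are said of these compounds alone.

Compound 2 `Clc1ccccc1Cn1nnc2c(NC3CCC3)nc(-c3ccccc3)nc21` carries a chloro group on the benzyl ring of the shared core and, in an assay on Cerebral cortex for displacement of a labelled ligand from adenosine receptor A1 (Bos taurus) (a lower number here means a stronger inhibitor, a higher number a weaker inhibitor), compound 2 gives 24 nM. Among the measured compounds shown here, this is the higher of the two numbers measured here: compound 1 `c1ccc(Cn2nnc3c(NC4CCC4)nc(-c4ccccc4)nc32)cc1`, which has hydrogen at that position, gives 5 nM, and the step of a 4.8-fold higher number from compound 1 to compound 2 (0.68 log units; beyond the scatter) is the only measured change in the set. Compound 3 `OCCCNc1nc(-c2ccccc2)nc2c1nnn2Cc1ccccc1Cl` has not yet been measured. It differs from compound 2 in 3-hydroxypropyl in place of cyclobutyl on a nitrogen on an aromatic ring. For the measured compounds named here, the one measured step concerns a chloro group on the benzyl ring and says nothing about exchanging the cyclobutylamino group; there is no measured comparison that bears directly on this change. Since the ring is replaced by an open chain bearing a hydroxyl, the outcome is uncertain, and a loss of potency seems more likely than a gain. The estimate for compound 3 is 120 nM, between 30 nM and 500 nM, a step of a 5.0-fold higher number from compound 2 to compound 3 (0.70 log units; beyond the scatter).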

Compound 3, inhibition constant: 33 nM
Estimate against measurement, compound 3: 3.6-fold (0.56 log units) above, within the range that was stated.
By their numbers in this assay, from the lowest: compound 1; then compounds 2 and 3 (each within the scatter of the next).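

In this assay, putting 3-hydroxypropyl in place of cyclobutyl on a nitrogen on an aromatic ring gives a 1.4-fold higher number from compound 2 to compound 3 (0.14 log units; within the scatter) and so leaves compound 2 and compound 3 indistinguishable. For this pair, then, the four-membered ring of carbon can give way to an open chain ending in a hydroxyl with no measurable cost, which the chloro step alone could not show. No available evidence explains why these two groups give such similar results.

From the compounds shown here alone, whether a 3-aminopropyl group, a carboxylic acid or a longer chain ending in a hydroxyl would be accepted equally well at this nitrogen remains open. Going by these compounds, it is also open whether 3-hydroxypropyl would match cyclobutyl on the core of compound 1, which has hydrogen in place of the chloro group.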